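Replacing chloro with ethoxy on the shared core

The source may report more compounds than this note shows. Statements on the series, on what has been measured and on what is new or still open speak of the compounds shown alone.

In a functional assay on MCF7 cells (Homo sapiens) for antiproliferative activity, read by MTT assay, with a stated time of 72 h (a lower number here means a stronger inhibitor, a higher number a weaker inhibitor), compound 1 (`COc1cc(-n2ncnc2-c2ccc(C)cc2)cc(OC)c1OC`) gives a measured 540 nM and carries a 4-methylphenyl group. Compound 2 (`COc1cc(-n2ncnc2-c2ccc(Cl)cc2)cc(OC)c1OC`) reads > 10000 nM which is a limit and not a number. Compound 3 (`COc1cc(-n2ncnc2-c2ccc(Cl)c(Cl)c2)cc(OC)c1OC`) reads > 10000 nM which is likewise a limit. Compound 2 thus rests on the limit of > 10000 nM in this assay, at which 2 of the 3 values shown sit, and has no number of its own.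

Within the data shown here, the change to compound 4 (`CCOc1ccc(-c2ncnn2-c2cc(OC)c(OC)c(OC)c2)cc1`) puts ethoxy in place of chloro on an aromatic carbon, a difference counted as ethoxy in place of chloro on an aromatic carbon and one for which no measured step involves ethoxy. The closest evidence is the exchange of methyl for chloro, which gave an at least 18-fold higher number from compound 1 to compound 2 (1.26 log units; beyond the scatter) and counts as large. The exchange for 3,4-dichlorophenyl gave an at least 18-fold higher number from compound 1 to compound 3 (1.26 log units; beyond the scatter) and is also large. The remaining comparison, a step that the two limits leave unreadable from compound 2 to compound 3 gives no guidance.

Compound 4, like compound 1, has no chloro on that ring, so a large move towards a lower number is expected, read backwards from an at least 18-fold higher number from compound 1 to compound 2 (1.26 log units; beyond the scatter) with caution, since ethoxy is not methyl. On these data alone, the estimated change is an at least 22-fold lower number from compound 2 to compound 4 (1.34 log units; beyond the scatter) and its true size stays open while compound 2 has only a limit. Compound 4 is expected at 450 nM with an estimated range from 50 nM to 6000 nM in this assay once measured.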

Compound 4, half-maximal inhibitory concentration: 50 nM
Beside the measured number, compound 4's estimate is 9.0-fold (0.95 log units) above it, within the range that was stated.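

In this assay, among these compounds, the position on an aromatic carbon para to a large group proves able to give a number well below that of methyl, which until now held the only measured value, so methyl no longer marks the best result seen at this position: ethoxy in place of methyl gives an 11-fold lower number from compound 1 to compound 4 (1.03 log units; beyond the scatter). Ethoxy in place of chloro gives an at least 200-fold lower number from compound 2 to compound 4 (2.30 log units; beyond the scatter), which shows that this one position spans a very wide range of results in this series, with the rest of the structure unchanged, and that ethoxy, with 3 heavy atoms and 1 hydrogen-bond acceptor against none for chloro, sits at the favourable end of that range. Compound 2 still has only a limit and not a number, so the true size of that step stays open: the limit of > 10000 nM in this assay, at which 2 of the 4 values shown sit.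

The compounds shown do not separate the oxygen of ethoxy from the length of its chain, a question that methoxy, propoxy or a plain propyl group at this position would address. On these data alone, how an amine such as dimethylamino, or a hydroxy group, would read at this position also remains open.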